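The source may report more compounds than this note shows. Statements on the series, on what has been measured and on what is new or still open speak of the compounds shown alone.

Compound 2 `Cc1nn(-c2ccccc2)cc1/C=N/Nc1nc(Nc2ccccc2)nc(Nc2ccc(S(N)(=O)=O)cc2)n1` is one of two measured compounds in this series. In a functional assay on MDA-MB-435 cells (Homo sapiens) for inhibition, read by sulforhodamine B assay, with a stated time of 48 h (on this read-out lower numbers stand for higher toxicity in this test and higher numbers for lower toxicity in this test), compound 2 gives 6780 nM, the lowest of the two numbers. Its nearest neighbour is compound 1 `NS(=O)(=O)c1ccc(Nc2nc(N/N=C/c3ccc(C(F)(F)F)cc3)nc(Nc3ccccc3)n2)cc1`, which in this assay gives 9530 nM; the change from compound 1 to compound 2 was a 1.4-fold lower number from compound 1 to compound 2 (0.15 log units; within the scatter), so the two values cannot be ranked against each other.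

Compound 3 `NS(=O)(=O)c1ccc(Nc2nc(N/N=C/c3ccccn3)nc(Nc3ccccc3)n2)cc1` differs from compound 2 in one place: pyridin-2-yl in place of 3-methyl-1-phenyl-1H-pyrazol-4-yl on a carbon with a double bond to nitrogen. For the measured compounds named here, the only measured step that bears on this is the one from compound 1 to compound 2, which also exchanged the group on this same carbon and which gave a 1.4-fold lower number from compound 1 to compound 2 (0.15 log units; within the scatter). On that basis no step beyond the scatter is expected from compound 2 to compound 3 in this assay, and the expected step is a 1.1-fold higher number from compound 2 to compound 3 (0.04 log units; within the scatter). The estimate for compound 3 in this assay is therefore 7500 nM, with a range from 3000 nM to 19000 nM.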

Compound 3, concentration lethal to 50% of the cells: 5930 nM
Compound 3: middle estimate off by 1.3-fold (0.10 log units), on the high side, within the range that was stated.
By their numbers in this assay, from the lowest: compounds 3, 2 and 1 (each within the scatter of the next).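

In this assay, the third group on the carbon with a double bond to nitrogen also gives no readable step: a 1.1-fold lower number from compound 2 to compound 3 (0.06 log units; within the scatter), and a 1.6-fold lower number from compound 1 to compound 3 (0.21 log units; within the scatter). Pyridin-2-yl therefore cannot be told apart from 3-methyl-1-phenyl-1H-pyrazol-4-yl or from 4-(trifluoromethyl)phenyl, so across these three compounds this exchange of aromatic groups leaves the read-out within the scatter. No evidence is available that would explain this result.

The compounds shown leave open whether any group at this place can move the number beyond the scatter, for example an amine or a carboxylic acid in place of these aromatic groups. They also leave open what the rest of the shared core contributes, since it is the same in all three compounds.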